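This account rests on a few compounds, and the source may have more. Where it says the series, first, only, none or still open, it means among the compounds named here.

Measured so far in an ADME assay on the whole organism (Mus musculus, strain Swiss Webster) for pharmacokinetics, read by LC-MS, at a dose of 50 mg/kg by the oral route; a higher number here means more compound in the circulation at the dose given, a lower number less compound in the circulation:
- Compound 1 `O=C(Nc1ccc(F)c(-c2nc3ncc(-c4cc(F)ccc4F)cc3[nH]2)c1)N1CCCC1`: 2800 nM
- Compound 2 `O=C(Nc1ccc(F)c(-c2nc3ncc(-c4ccc(O)cc4)cc3[nH]2)c1)N1CCCC1`: 130 nM
- Compound 3 `O=C(Nc1ccc(F)c(-c2nc3ncc(-c4cccc(F)c4)cc3[nH]2)c1)N1CCCC1`: 7000 nM

Compound 3 has the highest number of the three in this assay. Compound 1 is its nearest neighbour, and compound 2 lies far lower.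

Compound 4 `O=C(Nc1ccc(F)c(-c2nc3ncc(-c4cc(F)cc(F)c4)cc3[nH]2)c1)N1CCCC1` keeps all of compound 3 except at one spot: fluoro in place of hydrogen on an aromatic carbon. This is fluoro in place of hydrogen on an aromatic carbon, which turns 3-fluorophenyl into 3,5-difluorophenyl.

Going by the values given here, the closest precedent is a 2.5-fold higher number from compound 1 to compound 3 (0.40 log units; beyond the scatter), a modest step in which a fluoro gave way to hydrogen. Read backwards, it suggests that adding a fluoro could lower the number slightly, although compound 1 carries 2,5-difluorophenyl, a different pattern, so the guide is imperfect. The steps of a 22-fold lower number from compound 1 to compound 2 (1.33 log units; beyond the scatter) and a 54-fold higher number from compound 2 to compound 3 (1.73 log units; beyond the scatter) are large, but both involve 4-hydroxyphenyl, so they say little about a fluoro swap.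

A small fall is therefore expected, possibly no larger than the scatter. The expected change is a 1.6-fold lower number from compound 3 to compound 4 (0.19 log units; within the scatter). For compound 4 the estimated value is 4500 nM, with an expected range of 1800 nM to 11000 nM.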

Compound 4, maximal plasma concentration: 4800 nM
For compound 4 the middle estimate is 1.1-fold (0.03 log units) below the measured one; the measured number falls inside the stated range.
By their numbers in this assay, from the lowest: compound 2; then compounds 1, 4 and 3 (each within the scatter of the next, the first and the last beyond it).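

In this assay, adding a second fluoro to the 3-fluorophenyl ring to give 3,5-difluorophenyl produces a 1.5-fold lower number from compound 3 to compound 4 (0.16 log units; within the scatter), so compound 4 cannot be told apart from compound 3 and this position accepts the added fluoro without a measurable change. Replacing 2,5-difluorophenyl with 3,5-difluorophenyl gives a 1.7-fold higher number from compound 1 to compound 4 (0.23 log units; within the scatter), so the two difluorophenyl patterns also cannot be told apart, while a 37-fold higher number from compound 2 to compound 4 (1.57 log units; beyond the scatter) places a third fluorinated ring far from the 4-hydroxyphenyl of compound 2. No measurement shown here explains any of these numbers.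

The compounds shown leave open whether a different group at this position, such as a chloro, a methoxy or an amine, would keep the number in this assay close to those of compound 3 and compound 4. They also leave open whether a plain phenyl ring, with no substituent at all, would sit with the fluorinated rings or nearer to compound 2.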